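Aryl amine variation on the shared core: compound 4

This account rests on a few compounds, and the source may have more. Where it says the series, first, only, none or still open, it means among the compounds named here.

Measured so far:
compound 1, `O=C(NCCCNc1nc(Nc2cccnc2)ncc1C1CC1)C1CCC1`, 13 nM
compound 2, `O=C(NCCCNc1nc(Nc2cccc(F)c2)ncc1C1CC1)C1CCC1`, 8 nM
compound 3, `CN(C)Cc1ccc(Nc2ncc(C3CC3)c(NCCCNC(=O)C3CCC3)n2)cc1`, 6 nM

All three numbers come from an assay on isolated protein for inhibition of serine/threonine-protein kinase TBK1 (Homo sapiens); on this read-out lower numbers stand for stronger inhibition and higher numbers for weaker inhibition. Compound 3 holds the lowest number of the three. Its nearest neighbour is compound 2, which sits within the scatter of it; the gap to compound 1 is beyond the scatter, though modest.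

Compound 4, `Cn1ccc(Nc2ncc(C3CC3)c(NCCCNC(=O)C3CCC3)n2)n1`, is not yet measured. It differs from compound 3 in one place: 1-methyl-1H-pyrazol-3-yl in place of 4-((dimethylamino)methyl)phenyl on a nitrogen on an aromatic ring.

The three measured steps all exchange the group on the same nitrogen on an aromatic ring and therefore bear on this change. They were: a 1.6-fold lower number from compound 1 to compound 2 (0.21 log units; within the scatter); a 2.2-fold lower number from compound 1 to compound 3 (0.34 log units; beyond the scatter); a 1.3-fold lower number from compound 2 to compound 3 (0.12 log units; within the scatter). Across pyridin-3-yl, 3-fluorophenyl and 4-((dimethylamino)methyl)phenyl the read-out thus moved only a little, and the only step beyond the scatter was modest. No pyrazole has been measured in this position, so the direction for compound 4 is open; the recorded steps suggest a small change, possibly none beyond the scatter.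

Compound 4 is estimated at 15 nM, within 5 nM to 45 nM. That estimate means an expected step of a 2.5-fold higher number from compound 3 to compound 4 (0.40 log units; beyond the scatter).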

Compound 4, half-maximal inhibitory concentration: > 1000 nM
Compound 4 ended at the assay's limit; the forecaster's own chance of this, stated with the estimate: 2%; middle value at least 66-fold (1.82 log units) away from the limit.
By their numbers in this assay, from the lowest: compounds 3, 2 and 1 (each within the scatter of the next, the first and the last beyond it). At a limit, above all of these: compound 4.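

In this assay compound 4 carries a limit of the assay and not a number: the limit of > 1000 nM in this assay, at which 1 of the 4 values shown sits. Even read as limits, the steps to 1-methyl-1H-pyrazol-3-yl are all large: an at least 160-fold higher number from compound 3 to compound 4 (2.22 log units; beyond the scatter), an at least 120-fold higher number from compound 2 to compound 4 (2.09 log units; beyond the scatter) and an at least 76-fold higher number from compound 1 to compound 4 (1.88 log units; beyond the scatter), whereas the largest step among the earlier compounds is only a 2.2-fold lower number from compound 1 to compound 3 (0.34 log units; beyond the scatter). The group on this nitrogen on an aromatic ring is therefore not freely exchangeable, and the small steps among pyridin-3-yl, 3-fluorophenyl and 4-((dimethylamino)methyl)phenyl do not carry over to this five-membered aromatic ring with 2 hetero atoms.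

This single change alters the ring size, the hetero atoms and the substituent on the ring together, and the compounds shown do not separate these contributions. From the compounds shown here alone, it remains open whether a 1-methyl-1H-pyrazol-4-yl group, or a pyrazole bearing a (dimethylamino)methyl group, would return the read-out to the range of compound 1, compound 2 and compound 3, or whether a five-membered aromatic ring on this nitrogen fails in general.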